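From methoxy to hydroxy on compound 3

The compounds below may be only part of what the source reports. "The series", "measured", "known", "first", "only" and "open" are said of these compounds alone.

In a functional assay on MCF7 cells (Homo sapiens) for cytotoxicity, read by MTT assay, with a stated time of 72 h (on this read-out higher numbers stand for weaker inhibition and lower numbers for stronger inhibition), compound 1 (`COc1cccc(/C=C2\CCC/C(=C\c3cccc(Cl)c3)C2=O)c1OC`) gives 12000 nM, compound 2 (`COc1cccc(/C=C2\CCC/C(=C\c3ccc(Br)cc3)C2=O)c1OC`) gives 13800 nM and compound 3 (`COc1cccc(/C=C2\CCC/C(=C\c3cccc(OC)c3OC)C2=O)c1`) gives 5900 nM, the lowest number of the three. Compound 4 (`COc1cccc(/C=C2\CCC/C(=C\c3cccc(O)c3)C2=O)c1OC`) has not been measured. Relative to compound 3 it carries this change: hydrogen in place of methyl on an oxygen on an aromatic ring, which turns 3-methoxyphenyl into 3-hydroxyphenyl. Among the compounds with values here, no measured step makes this exact change. The closest are a 2.0-fold lower number from compound 1 to compound 3 (0.31 log units; beyond the scatter), with methoxy in place of chloro, and a 2.3-fold lower number from compound 2 to compound 3 (0.37 log units; beyond the scatter), both modest. A step beyond the scatter in this assay is therefore not expected, and neither direction is favoured. The expected change is a 1.0-fold higher number from compound 3 to compound 4 (0.01 log units; within the scatter). For compound 4 the estimate is 6000 nM, with an expected range of 2000 nM to 16000 nM.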

Compound 4, half-maximal inhibitory concentration: 8800 nM
Compound 4: middle estimate off by 1.5-fold (0.17 log units), on the low side, within the range that was stated.
By their numbers in this assay, from the lowest: compounds 3, 4, 1 and 2 (each within the scatter of the next, the first and the last beyond it).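

In this assay, hydrogen in place of methyl on this oxygen gives a 1.5-fold higher number from compound 3 to compound 4 (0.17 log units; within the scatter) and so does not separate 3-hydroxyphenyl from 3-methoxyphenyl. Compound 4 also stays within the scatter of both halogen compounds, with a 1.4-fold lower number from compound 1 to compound 4 (0.13 log units; within the scatter) for hydroxy in place of chloro and a 1.6-fold lower number from compound 2 to compound 4 (0.20 log units; within the scatter) for 3-hydroxyphenyl in place of 4-bromophenyl, although compound 3 lies beyond the scatter of each. Compound 4 thus closes no gap and opens none. Going by these compounds, whether an amine or a longer chain on this oxygen would give a step beyond the scatter remains open. No evidence here accounts for these results.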